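The compounds below may be only part of what the source reports. "The series", "measured", "known", "first", "only" and "open" are said of these compounds alone.

Measured in a functional assay on PC-3 cells (Homo sapiens) for inhibition, read by sulforhodamine B assay, with a stated time of 48 h; on this read-out higher numbers stand for weaker inhibition of growth and lower numbers for stronger inhibition of growth:
Compound 1 `CCOC(=O)c1nn(-c2ccccc2)c(-c2ccc(Br)cc2)c1CNC(C)(C)C`: 15900 nM; > 509000 nM (2 entries)
Compound 2 `CC(C)(C)NCc1c(C(=O)O)nn(-c2ccccc2)c1-c1ccc(Br)cc1`: > 585000 nM

The two entries for compound 1 are one number and one limit. Compound 2 stands only at a limit, > 585000 nM, and has no single number. Compound 3 `CC(C)(C)NCc1c(C(=O)O)nn(-c2ccccc2)c1-c1ccc([N+](=O)[O-])cc1` has nitro in place of bromo on an aromatic carbon, para to a large group: nitro in place of bromo on an aromatic carbon. The expectation in this assay rests solely on the limit of compound 2, > 585000 nM. Expected is a step that the limit leaves unreadable from compound 2 to compound 3, meaning no change beyond the scatter. For compound 3 the estimated value is 600000 nM, with an expected range from 200000 nM to 1000000 nM.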

Compound 3, concentration for 50% growth inhibition: > 634000 nM
Compound 3 gave a limit, no number (the forecaster's own chance of this, stated with the estimate: 85%); at least 1.0-fold (0.02 log units) between middle value and limit.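

No step can be read from compound 2 to compound 3: in this assay each stands only at a limit, with no single number. As far as these compounds go, whether nitro in place of bromo changes growth inhibition at all remains open.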